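The source may hold more compounds than are shown below. What is called first, only, known or untested is meant among the compounds shown, and "the series" means these compounds.

Compound 1 `Nc1ccccc1NC(=O)c1ccc(CSC(=S)N2CCN(c3ccccc3)CC2)cc1` gives 88.6% in a functional assay on A-375 cells (Homo sapiens) for antiproliferative activity, read by CCK-8 assay, with a stated time of 72 h, tested at 8 uM; on this read-out lower numbers stand for a weaker effect and higher numbers for a stronger effect at the one concentration tested. Compound 2 `Nc1ccccc1NC(=O)c1ccc(CSC(=S)N2CCc3ccccc32)cc1` gives 85.4% in this assay, and compound 3 `Nc1ccccc1NC(=O)c1ccc(CSC(=S)N2CCN(Cc3cccnc3)CC2)cc1` gives 89.2% in this assay. Compound 2 stands at the lowest of the three numbers shown, but its gaps to compound 1 and to compound 3 both lie within the scatter, so the three compounds are not separated by this read-out. Among the measured compounds shown here, the only step between measured compounds that differ in a single place, a number 0.6 percentage points higher from compound 1 to compound 3 (within the scatter), is likewise within the scatter.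

Compound 4 `Nc1ccccc1NC(=O)c1ccc(CSC(=S)N2CCCC2)cc1` has not yet been measured in this assay. It differs from compound 2 by pyrrolidin-1-yl in place of 2,3-dihydro-1H-indol-1-yl on a thiocarbonyl carbon. For the measured compounds named here, no measured step alters the group on the thiocarbonyl carbon, so the step from compound 1 to compound 3 does not bear on this change directly; it shows only that swapping one amine substituent for another kept the read-out within the scatter. With nothing pointing either way, no step beyond the scatter is expected in this assay in either direction, and the estimated step is a number 1.4 percentage points lower from compound 2 to compound 4 (within the scatter). Compound 4 is therefore expected to give about 84%, with a range from 72% to 93%.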

Compound 4, a percentage reported as inhibition, at one concentration (the size of the read-out at that concentration, not a potency): 89.5%
The estimate for compound 4 lay 5.5 percentage points below the measured number, and the stated range covers the measured number.
By their numbers in this assay, from the lowest: compounds 2, 1, 3 and 4 (each within the scatter of the next).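

Among the compounds shown here, this is the first measured change of the group on the thiocarbonyl carbon, and in this assay it gives a number 4.1 percentage points higher from compound 2 to compound 4 (within the scatter). At this position, pyrrolidin-1-yl, with 5 heavy atoms and one five-membered non-aromatic ring, therefore cannot be told apart from 2,3-dihydro-1H-indol-1-yl, with 9 heavy atoms and an additional six-membered aromatic ring of carbon only, so that aromatic ring is not required to keep the read-out at this level at the one concentration tested. No available evidence bears on why this change leaves the read-out within the scatter.

The compounds shown leave open whether an open-chain amine such as diethylamino, or a ring carrying oxygen such as morpholin-4-yl, on the thiocarbonyl carbon would also stay within the scatter of compound 4. They also leave open whether compound 2 and compound 4, which this single-concentration read-out does not separate, would differ in the size of their effect at other concentrations.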